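Hydroxyphenyl positional isomers: cytotoxicity working notes

The compounds below may be only part of what the source reports. "The series", "measured", "known", "first", "only" and "open" are said of these compounds alone.

Measured so far in an ADME assay on HEK293 cells (Homo sapiens) for cytotoxicity, read by CCK-8 assay, with a stated time of 4 days; a higher number here means a weaker inhibitor, a lower number a stronger inhibitor:
compound 1 `Oc1ccc(-c2cc(-c3ccccc3O)cc(-c3cccc(O)c3)n2)cc1` gives 5650 nM
compound 2 `Oc1ccc(-c2cc(-c3cccc(O)c3)nc(-c3cccc(O)c3)c2)cc1` gives 730 nM
compound 3 `Oc1ccc(-c2cc(-c3cccc(O)c3)cc(-c3cccc(O)c3)n2)cc1` gives 1560 nM

Compound 3 stands second highest of the three numbers; compound 2 lies nearest and compound 1 furthest.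

Compound 4 `Oc1ccc(-c2cc(-c3ccc(O)cc3)nc(-c3cccc(O)c3)c2)cc1` differs from compound 3 by 4-hydroxyphenyl in place of 3-hydroxyphenyl on an aromatic carbon. Within the data shown here, no measured step covers this exact change. Among the measured compounds shown here, the only single-point step, a 3.6-fold lower number from compound 1 to compound 3 (0.56 log units; beyond the scatter), also shifted a hydroxyl within one ring and was modest. Compound 2 and compound 3 carry the same groups in a different arrangement and their values stand close together. A modest step at most is therefore expected in this assay, direction uncertain, a slightly lower number favoured. Compound 4 is estimated at 1200 nM (range 400 nM to 3600 nM), an expected step of a 1.3-fold lower number from compound 3 to compound 4 (0.11 log units; within the scatter).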

Compound 4, half-maximal inhibitory concentration: 840 nM
Estimate against measurement, compound 4: 1.4-fold (0.15 log units) above, within the range that was stated.
By their numbers in this assay, from the lowest: compounds 2, 4 and 3 (each within the scatter of the next, the first and the last beyond it); then compound 1.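

In this assay, 4-hydroxyphenyl in place of 3-hydroxyphenyl opposite the ring nitrogen stays within the scatter on both comparisons (a 1.9-fold lower number from compound 3 to compound 4 (0.27 log units; within the scatter); a 1.2-fold higher number from compound 2 to compound 4 (0.06 log units; within the scatter)). Among these compounds, the only new step beyond the scatter (a 6.7-fold lower number from compound 1 to compound 4 (0.83 log units; beyond the scatter)) replaces 2-hydroxyphenyl, the same group replaced in the earlier step (a 3.6-fold lower number from compound 1 to compound 3 (0.56 log units; beyond the scatter)). Compound 3 and compound 4 therefore do not separate, while compound 1 stands apart from both. No available evidence accounts for these numbers. Going by these compounds, the effect of an amine or a carboxylic acid in place of the hydroxyl at this position remains open.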